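The source may hold more compounds than are shown below. What is called first, only, known or untested is meant among the compounds shown, and "the series" means these compounds.

Compound 2 `N#CC1CN1C(=O)Nc1ccc(S(N)(=O)=O)cc1` is the starting point, and its standing in a functional assay on RPMI-8226 cells (Homo sapiens) for inhibition (a lower number here means a stronger inhibitor, a higher number a weaker inhibitor), is known only as a limit: compound 2 gives > 38000 nM. That is the limit of > 38000 nM in this assay, at which 1 of the 3 values shown sits. Two other members of the series have full numbers: compound 1 `N#CC1CN1C(=O)Nc1ccc(Cl)c(Cl)c1` gives 1100 nM in this assay, and compound 3 `CCOC(=O)CNC(=O)N1CC1C#N` gives 25000 nM in this assay. The unmeasured compound 4 `N#CC1CN1C(=O)Nc1ccc(C(F)(F)F)cc1` differs from compound 2 by one change, (trifluoromethyl in place of sulfamoyl on an aromatic carbon). For the measured compounds named here, with no measured pair separated by this same change, the size of the step cannot be read off directly, and the limit on compound 2 leaves only its direction open to guesswork. Compound 4 is expected to be the stronger inhibitor because compound 1 gives 1100 nM in this assay, so a step of an at least 15-fold lower number from compound 2 to compound 4 (1.18 log units; beyond the scatter) is estimated. Compound 4 is therefore expected to give 2500 nM in this assay, within 700 nM to 9000 nM.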

Compound 4, half-maximal inhibitory concentration: 8200 nM
Estimate against measurement, compound 4: 3.3-fold (0.52 log units) below, within the range that was stated.
By their numbers in this assay, from the lowest: compound 1; then compound 4; then compound 3. At a limit, above all of these: compound 2.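

Trifluoromethyl in place of sulfamoyl on this aromatic carbon gives an at least 4.6-fold lower number from compound 2 to compound 4 (0.66 log units; beyond the scatter) in this assay. For the compounds shown here, this is the first single-place step, and it shows that the group on this carbon changes the read-out, with the group lacking hydrogen-bond donors and acceptors on the stronger side. The size is only a bound, as the value for compound 2 is a limit: the limit of > 38000 nM in this assay, at which 1 of the 4 values shown sits.

Going by these compounds alone, no steps to compound 1 or compound 3 can be read. On these data alone, how an amine, a carboxylic acid or a methoxy group on this carbon would compare remains open.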